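Swapping 2-methylphenyl for 4-fluorophenyl on an oxygen

The source may report more compounds than this note shows. Statements on the series, on what has been measured and on what is new or still open speak of the compounds shown alone.

Three compounds have readings in an ADME assay on Vero cells (Chlorocebus sabaeus) for inhibition, read by MTT assay, with a stated time of 72 h (a lower number here means a stronger inhibitor, a higher number a weaker inhibitor), so far. Compound 1 `COC(=O)CCCCCCC(=O)Nc1cccc(OS(=O)(=O)C2CC3OC2C(c2ccc(O)cc2)=C3c2ccc(O)cc2)c1` gives > 100000 nM as a limit of the assay. Compound 3 `O=C(O)CCCCCCC(=O)Nc1ccc(OS(=O)(=O)C2CC3OC2C(c2ccc(O)cc2)=C3c2ccc(O)cc2)cc1` gives > 100000 nM as a limit too. Compound 2 `Cc1ccccc1OS(=O)(=O)C1CC2OC1C(c1ccc(NC(=O)CCCCCCC(=O)O)cc1)=C2c1ccc(O)cc1` gives > 100000 nM as a limit and not a number. The set thus shows the limit of > 100000 nM in this assay, at which 3 of the 3 values shown sit, and no ranking. Compound 4 `O=C(O)CCCCCCC(=O)Nc1ccc(C2=C(c3ccc(O)cc3)C3CC(S(=O)(=O)Oc4ccc(F)cc4)C2O3)cc1` differs from compound 2 by 4-fluorophenyl in place of 2-methylphenyl on an oxygen in one place, with 4-fluorophenyl in place of 2-methylphenyl on an oxygen. Among the compounds with values here, no measured step shows what this change does. The expected a number no higher from compound 2 to compound 4 (the limit leaves the size open) is none beyond the scatter, with no direction favoured. This expectation rests on compound 2 with its limit > 100000 nM as the only reference. For compound 4 the estimated value is 100000 nM with an expected range from 40000 nM to 200000 nM and a reading as a limit is likely.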

Compound 4, half-maximal inhibitory concentration: > 100000 nM
Compound 4: only a limit was reported; the forecaster's own chance of this, stated with the estimate: 85%; the middle value lies on the limit itself.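

In this assay compound 2 gives > 100000 nM, a limit and not a number. Within the data shown here, compound 4 gives > 100000 nM, also a limit, and no step from compound 2 to compound 4 can be read. The compounds shown leave open how 4-fluorophenyl and 2-methylphenyl on an oxygen compare, and any ranking in this assay: the limit of > 100000 nM in this assay, at which 4 of the 4 values shown sit.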